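Swapping the Cyclohexyl Arm of a Kinase Inhibitor

The source may report more compounds than this note shows. Statements on the series, on what has been measured and on what is new or still open speak of the compounds shown alone.

Compound 1 `N#Cc1cnc(NCc2cnccc2C(F)(F)F)cc1NC[C@H]1C[C@H](O)C1`: 700 nM
Compound 2 `CO[C@H]1CC[C@@H](CNc2cc(NCc3cnccc3C(F)(F)F)ncc2C#N)CC1`: 70 nM

Among the measured compounds shown here, in an assay on isolated protein for inhibition of protein kinase C theta type (Homo sapiens), read by TR-FRET, with a stated time of 2 h (a lower number here means a stronger inhibitor, a higher number a weaker inhibitor), compound 2 gives the lower of the two numbers, and the only measured step, a 10-fold lower number from compound 1 to compound 2 (1.00 log units; beyond the scatter), came from reshaping the same side chain. Compound 3 `CNC(=O)[C@H]1CC[C@@H](Nc2cc(NCc3cnccc3C(F)(F)F)ncc2C#N)CC1` differs from compound 2 by 4-(methylcarbamoyl)cyclohexyl in place of (4-methoxycyclohexyl)methyl on a nitrogen on an aromatic ring. For the measured compounds named here, no measured step matches this exchange, which removes the linking carbon and brings in a hydrogen-bond donor, so only a weak lead can be taken from it; a step of roughly a 2.1-fold higher number from compound 2 to compound 3 (0.33 log units; beyond the scatter) is expected, a mild weakening that may stay near the scatter. Compound 3 is therefore estimated at 150 nM, between 40 nM and 600 nM.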

Compound 3, half-maximal inhibitory concentration: 27 nM
For compound 3 the middle estimate is 5.6-fold (0.74 log units) above the measured one, and the stated range ends above it.
By their numbers in this assay, from the lowest: compound 3; then compound 2; then compound 1.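

At this position on a nitrogen on an aromatic ring, the linking carbon can go and an amide can come in with a 2.6-fold lower number from compound 2 to compound 3 (0.41 log units; beyond the scatter) in this assay, so a hydrogen-bond donor on the cyclohexyl ring is tolerated here. Replacing the (3-hydroxycyclobutyl)methyl arm gives a 26-fold lower number from compound 1 to compound 3 (1.41 log units; beyond the scatter) as the largest step in this set. No evidence here explains why the number fell.

On these data alone, compound 3 changes the linker and the end group together, so their separate contributions remain unknown. As far as these compounds go, whether a carboxylic acid or an amine in place of the methylcarbamoyl group would hold this strength also remains open.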